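Benzyl in place of 3-methoxyphenyl on an amine nitrogen

The source may report more compounds than this note shows. Statements on the series, on what has been measured and on what is new or still open speak of the compounds shown alone.

Compound 1 `O=C1C(N2CCCC2)=CC(=O)c2c1nc1n2[C@H]2OC[C@@H](O)[C@H]2OC1`: > 16000 nM (a limit)
Compound 2 `COc1cccc(NC2=CC(=O)c3c(nc4n3[C@H]3OC[C@@H](O)[C@H]3OC4)C2=O)c1`: 1790 nM

Going by the values given here, in a functional assay on MGC-803 cells (Homo sapiens) for inhibition, read by sulforhodamine B assay (a lower number here means a stronger inhibitor, a higher number a weaker inhibitor), compound 2 gives 1790 nM, the only actual number so far. Compound 1 stands at the limit of > 16000 nM in this assay, at which 1 of the 2 values shown sits, and that is a limit, not a number.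

Compound 3 `O=C1C(NCc2ccccc2)=CC(=O)c2c1nc1n2[C@H]2OC[C@@H](O)[C@H]2OC1` has yet to be measured. It carries benzyl in place of 3-methoxyphenyl on an amine nitrogen whose other neighbour is a double-bonded ring carbon: benzyl in place of 3-methoxyphenyl on an amine nitrogen.

Among the compounds with values here, only one measured step bears on this change, the exchange of pyrrolidin-1-yl for (3-methoxyphenyl)amino on a double-bonded ring carbon, an at least 8.9-fold lower number from compound 1 to compound 2 (0.95 log units; beyond the scatter). It shows that this assay can respond to the group at this place, but it replaces more of the structure than the present change does. Compound 3 keeps a six-membered aromatic ring of carbon only, as compound 2 does, so a smaller move than an at least 8.9-fold lower number from compound 1 to compound 2 (0.95 log units; beyond the scatter) is expected, leaning towards a higher number. Within the data shown here, no measured compound tests benzyl directly, so the direction is uncertain.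

The expected change is a 2.0-fold higher number from compound 2 to compound 3 (0.29 log units; within the scatter). Compound 3 is estimated at 3500 nM, with an expected range from 1000 nM to 12000 nM.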

Compound 3, half-maximal inhibitory concentration: 3490 nM
For compound 3 the middle estimate is 1.0-fold (0.00 log units) above the measured one; measured number inside the range.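

In this assay, benzyl in place of 3-methoxyphenyl on the amine nitrogen gives a 1.9-fold higher number from compound 2 to compound 3 (0.29 log units; within the scatter), so this place tolerates the loss of the oxygen of 3-methoxyphenyl and the change in how the six-membered aromatic ring is attached, with no difference that can be read. Benzylamino in place of pyrrolidin-1-yl on the double-bonded ring carbon gives an at least 4.5-fold lower number from compound 1 to compound 3 (0.66 log units; beyond the scatter), which shows that the drop seen with compound 2 is not confined to the (3-methoxyphenyl)amino group. Compound 1 holds a limit and not a number, so neither step from it has a full size: the limit of > 16000 nM in this assay, at which 1 of the 3 values shown sits.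

The compounds shown leave open whether the aromatic ring is needed at all, a question that an open-chain amine such as butylamino would address by keeping the secondary amine without the ring. They also leave open how far the ring can be moved from the nitrogen or decorated, which a longer chain such as 2-phenylethyl or a chlorine on the benzyl ring would begin to test.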